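This account rests on a few compounds, and the source may have more. Where it says the series, first, only, none or still open, it means among the compounds named here.

Values in a functional assay on MCF7 cells (Homo sapiens) for inhibition, read by CCK-8 assay, with a stated time of 48 h (a higher number here means a weaker inhibitor of growth, a lower number a stronger inhibitor of growth), are as follows:
- compound 1 `CN1CCN(c2ccc(Nc3ncc(Cl)c(NCc4ccc(C(F)(F)F)cc4)n3)nc2)CC1` gives 28400 nM
- compound 2 `CN1CCN(c2ccc(Nc3ncc(Cl)c(NCc4ccc(F)cc4)n3)nc2)CC1` gives 19300 nM
- compound 3 `CC(C)c1ccc(Nc2nc(Nc3ccc(N4CCN(C)CC4)cn3)ncc2Cl)cc1` gives 1880 nM

Compound 3 stands lowest of the three, with a 15-fold lower number from compound 1 to compound 3 (1.18 log units; beyond the scatter) and a 10-fold lower number from compound 2 to compound 3 (1.01 log units; beyond the scatter) both large and beyond the scatter. By contrast, a 1.5-fold lower number from compound 1 to compound 2 (0.17 log units; within the scatter) stays within the scatter.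

Compound 4 `CC(C)c1cccc(Nc2nc(Nc3ccc(N4CCN(C)CC4)cn3)ncc2Cl)c1` has the same atoms as compound 3, joined differently. The change reads 3-isopropylphenyl in place of 4-isopropylphenyl on a nitrogen on an aromatic ring and amounts to 3-isopropylphenyl in place of 4-isopropylphenyl on a nitrogen on an aromatic ring.

Among the compounds with values here, no measured step makes this kind of change. Only the two large steps touch this place, and each exchanges the whole group, so neither gives the size of this one. A step within the scatter is therefore expected, leaning slightly towards a higher number. The estimated step is a 1.3-fold higher number from compound 3 to compound 4 (0.12 log units; within the scatter) and remains an expectation. In this assay compound 4 is expected at 2500 nM within an estimated range of 900 nM to 6000 nM as the working figure.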

Compound 4, concentration for 50% growth inhibition: 8640 nM
Estimate against measurement, compound 4: 3.5-fold (0.54 log units) below; measured number above the stated range.
By their numbers in this assay, from the lowest: compound 3; then compound 4; then compounds 2 and 1 (each within the scatter of the next).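

In this assay, shifting the isopropyl group with the atoms otherwise unchanged gives a 4.6-fold higher number from compound 3 to compound 4 (0.66 log units; beyond the scatter), so the point of attachment on this phenyl ring alone moves the number beyond the scatter, and 4-isopropylphenyl gives the lower number of the two. Compound 4 still keeps a lower number than both benzyl compounds, with a 2.2-fold lower number from compound 2 to compound 4 (0.35 log units; beyond the scatter) and a 3.3-fold lower number from compound 1 to compound 4 (0.52 log units; beyond the scatter), so only part of the large advantage of compound 3 over those compounds is lost, although these two steps exchange the whole group. Nothing available accounts for the gap between the two isomers.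

Still open, going by these compounds, is how a phenyl without the isopropyl group, or a phenyl carrying a methoxy or tert-butyl group, would read on this nitrogen. Also open, on these data alone, is whether a shift of this size recurs with ethyl in place of isopropyl.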